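Cytotoxicity notes on a shared-core series, compounds 1 to 3

The source may hold more compounds than are shown below. What is called first, only, known or untested is meant among the compounds shown, and "the series" means these compounds.

Measured in a functional assay on RD cells (Homo sapiens) for inhibition, read by luminescence and ATP content, with a stated time of 72 h; a higher number here means that more compound is tolerated, a lower number that less compound is tolerated:
- compound 1 `CC(C)c1ccc(-c2ccc3ncc(-c4noc(C(F)(F)F)n4)cc3c2)cc1` gives > 200000 nM, a limit of the assay.
- compound 2 `Fc1ccc(-c2ccc3ncc(-c4noc(C(F)(F)F)n4)cc3c2)cc1` gives > 7400 nM, also a limit of the assay.

Compound 2 therefore stands only at a limit, with no number behind it. The step that the two limits leave unreadable from compound 1 to compound 2 cannot be sized, since one end rests on the limit of > 200000 nM in this assay, at which 1 of the 2 values shown sits, and the other on (the limit of > 7400 nM in this assay, at which 1 of the 2 values shown sits).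

Compound 3 `CN(C)c1ccc(-c2ccc3ncc(-c4noc(C(F)(F)F)n4)cc3c2)cc1` carries the change (dimethylamino in place of fluoro on an aromatic carbon). Among the measured compounds shown here, no measured step bears on this change with a readable size; both values shown for the shared core are limits, and the scatter cannot be set against them. The expectation is therefore that compound 3 is tolerated in this assay much as compound 2 is, with a step that the limit leaves unreadable from compound 2 to compound 3 that may be no more than the scatter. Compound 3 is estimated at 30000 nM, within 7400 nM to 200000 nM, most likely again reported only as a limit.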

Compound 3, half-maximal cytotoxic concentration: > 22200 nM
Compound 3 gave a limit, no number (the forecaster's own chance of this, stated with the estimate: 70%); the middle value is on the limit's open side.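

In this assay compound 3 gives > 22200 nM, a limit of the assay. Among the compounds shown here, no step among compound 1, compound 2 and compound 3 can be read: all three values are limits. Left open is the concentration at which any of them becomes cytotoxic, and whether isopropyl, fluoro and dimethylamino differ at all in this assay.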